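The source may report more compounds than this note shows. Statements on the series, on what has been measured and on what is new or still open speak of the compounds shown alone.

Measured so far:
Compound 1 `COc1cc(-c2cc(/C=C/C(=O)c3ccc(N)cc3)[nH]n2)cc(OC)c1OC` gives -84% in a functional assay on UO-31 cells (Homo sapiens) for cytotoxicity, read by sulforhodamine B assay, with a stated time of 48 h, tested at 10 uM; on this read-out lower numbers stand for a stronger effect and higher numbers for a weaker effect at the one concentration tested.
Compound 2 `COc1ccc(-c2cc(/C=C/C(=O)c3ccc(N)cc3)[nH]n2)cc1OC` gives 11% in this assay.
Compound 3 `COc1cc(C(=O)/C=C/c2cc(-c3cc(OC)c(OC)c(OC)c3)n[nH]2)cc(OC)c1OC` gives -95% in this assay.

Compound 1 and compound 2 differ in one place, by hydrogen in place of methoxy on an aromatic carbon, and this single change made a step of a number 95 percentage points higher from compound 1 to compound 2 (beyond the scatter), so that compound 2 barely affects the cells under these conditions while compound 1 acts strongly. Compound 3 stands lowest of the three, and the difference between its core and the core of compound 1 is not broken down here.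

Compound 4 `COc1ccc(-c2cc(/C=C/C(=O)c3cc(OC)c(OC)c(OC)c3)[nH]n2)cc1OC` has not yet been measured. Among the compounds with values here, it differs from compound 3 by hydrogen in place of methoxy on an aromatic carbon, which is the same change, in the same surroundings, as the one seen between compound 1 and compound 2. On that basis the step of a number 95 percentage points higher from compound 3 to compound 4 (beyond the scatter) is expected to be of a size comparable to the earlier one, resting on compound 1 and the step of a number 95 percentage points higher from compound 1 to compound 2 (beyond the scatter). Within the data shown here, only one such example exists, so the expectation carries a wide range. Compound 4 is therefore estimated at 0% in this assay, expected to fall between -45% and 30%.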

Compound 4, a percentage reported as activity, at one concentration (the size of the read-out at that concentration, not a potency): -95%
Beside the measured number, compound 4's estimate is 95 percentage points above it, and the stated range ends above it.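

Replacing one methoxy group with hydrogen gave no change at the digits printed from compound 3 to compound 4 (within the scatter) in this assay, so the large step seen on the core of compound 1 did not carry over to the core of compound 3. Together, the two pairs show that in this series the size of the step from this change depends on the core that carries it: the same change on two cores in this assay, a number 95 percentage points higher (beyond the scatter) from compound 1 to compound 2 and no change at the digits printed (within the scatter) from compound 3 to compound 4, 95 percentage points apart, beyond the scatter of two such steps

Within the data shown here, with only two pairs, they do not show which part of the cores accounts for the difference, or what the same change would do on a further core. The compounds shown leave open what another group at this place, such as a hydroxyl, an ethoxy or a chlorine, would do on either core. They also leave open how the two pairs would compare at lower concentrations, since this assay gives a reading at one concentration only and is not a measure of potency.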